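This account rests on a few compounds, and the source may have more. Where it says the series, first, only, none or still open, it means among the compounds named here.

Of the compounds shown here, three sharing one core have been measured in a functional assay on SNB-75 cells (Homo sapiens) for inhibition, read by sulforhodamine B assay, with a stated time of 48 h, tested at 10 uM; on this read-out lower numbers stand for a stronger effect and higher numbers for a weaker effect at the one concentration tested. Compound 1 `COc1cc(Cl)cc(-c2nn(-c3cccc(NC(=O)c4ccc(Cl)c(Cl)c4)c3)cc2-c2ccncc2)c1` gives 50.6%. Compound 2 `O=C(Nc1cccc(-n2cc(-c3ccncc3)c(-c3cc(O)cc(Cl)c3)n2)c1)Nc1ccc(Cl)c(C(F)(F)F)c1` gives 24.1%, the second highest of the three numbers: its nearest neighbour is compound 3 `O=C(Nc1cccc(-n2cc(-c3ccncc3)c(-c3cc(O)cc(Cl)c3)n2)c1)Nc1ccc(Cl)c(Cl)c1`, and compound 3 gives 4.08%, while compound 1 stands furthest from it. Among the compounds with values here, the only step between compounds that differ in a single place is a number 20 percentage points lower from compound 2 to compound 3 (beyond the scatter), chloro in place of trifluoromethyl on an aromatic carbon; it does not touch the oxygen that changes here and so bears only indirectly on the step at hand. Compound 4 `COc1cc(Cl)cc(-c2nn(-c3cccc(NC(=O)Nc4ccc(Cl)c(C(F)(F)F)c4)c3)cc2-c2ccncc2)c1` differs from compound 2 by methyl in place of hydrogen on an oxygen on an aromatic ring. Within the data shown here, no measured pair isolates this change. Among the measured compounds shown here, compound 1 also carries a methoxy group, but it differs from compound 2 in more than one place, so its value shows only that a methoxy-bearing member of this series can give a high number. With that weak guidance, compound 4 is estimated at 35%, expected to lie between 15% and 60%, which means an expected step of a number 10.9 percentage points higher from compound 2 to compound 4 (beyond the scatter).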

Compound 4, a percentage reported as activity, at one concentration (the size of the read-out at that concentration, not a potency): 14.5%
Compound 4: the middle estimate sits 20.5 percentage points above what was measured; measured number outside the range, below it.
By their numbers in this assay, from the lowest: compound 3; then compounds 4 and 2 (each within the scatter of the next); then compound 1.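

In this assay, within the data shown here, the hydroxy to methoxy change on the aromatic ring, seen here in isolation for the first time, gives a number 9.6 percentage points lower from compound 2 to compound 4 (within the scatter), so at this position, with the rest of compound 2 held fixed, the oxygen accepts a methyl group without a step that can be told from the scatter. The high number of compound 1 therefore does not follow from its methoxy group alone: (4-chloro-3-(trifluoromethyl)phenyl)amino in place of 3,4-dichlorophenyl on the carbonyl carbon gives a number 36.1 percentage points lower from compound 1 to compound 4 (beyond the scatter), a far larger step than the one at the oxygen. Nothing available explains either step.

The compounds shown leave open whether a longer chain such as ethoxy, or an amine in place of the hydroxy group, would be accepted equally at this position. They also leave open whether methoxy would be accepted as readily alongside the aromatic chloro of compound 3, which gives 4.08%.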